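Hydroxymethyl added to a furan-bearing aminothiazolopyrimidine

The compounds below may be only part of what the source reports. "The series", "measured", "known", "first", "only" and "open" are said of these compounds alone.

Of the compounds shown here, two sharing one core have been measured in an assay on CHO cells for displacement of a labelled ligand from adenosine receptor A1 (Homo sapiens), read by scintillation counting, with a stated time of 3 h; a lower number here means a stronger inhibitor, a higher number a weaker inhibitor. Compound 1 `Nc1nc(-c2cccc(CO)c2)nc2sc(-c3ccccc3)nc12` carries a phenyl on the thiazole portion and a hydroxymethyl on the six-membered aromatic ring; in this assay compound 1 gives 32 nM. Compound 2 `Nc1nc(-c2ccccc2)nc2sc(-c3ccco3)nc12` carries a furan on the thiazole portion and an unsubstituted six-membered aromatic ring; in this assay compound 2 gives 33 nM. For the measured compounds named here, the two numbers sit within the usual scatter of each other, so neither compound can be called the more potent, and as the two structures differ in two places at once no single step between them is defined.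

Compound 3 `Nc1nc(-c2cccc(CO)c2)nc2sc(-c3ccco3)nc12` keeps the furan of compound 2 and adds the group found in compound 1: hydroxymethyl in place of hydrogen on an aromatic carbon. Nothing in the two measured values points to a large effect of this change in either direction. The estimate is that the step of a 1.3-fold lower number from compound 2 to compound 3 (0.12 log units; within the scatter) stays within the scatter. Compound 3 is therefore expected to give about 25 nM, with a likely range from 10 nM to 60 nM.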

Compound 3, inhibition constant: 28 nM
For compound 3 the middle estimate is 1.1-fold (0.05 log units) below the measured one; the range from low to high includes it.
By their numbers in this assay, from the lowest: compounds 3, 1 and 2 (each within the scatter of the next).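

In this assay, the change from hydrogen to hydroxymethyl on an aromatic carbon, meta to a large group, can now be read on its own, as a 1.2-fold lower number from compound 2 to compound 3 (0.07 log units; within the scatter), and with the furan in place this position takes the added group without a shift that can be told from the scatter. For the compounds shown here, the exchange on the other side of the molecule can also be read separately for the first time: with the hydroxymethyl kept, furan-2-yl in place of phenyl on an aromatic carbon gives a 1.1-fold lower number from compound 1 to compound 3 (0.06 log units; within the scatter), so this change likewise stays within the scatter. Nothing available here bears on why either step is so small.

On these data alone, it remains open whether another group at this position, such as an amine, a carboxylic acid or a longer chain, would produce a step beyond the scatter. As far as these compounds go, it also remains open whether hydroxymethyl in place of hydrogen would give a similar step with phenyl rather than furan on the shared core.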